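The source may report more compounds than this note shows. Statements on the series, on what has been measured and on what is new or still open speak of the compounds shown alone.

Measured compounds:
Compound 1, `NC(=O)c1c(NC(=O)c2ccc(C(F)(F)F)cc2)sc2c1CCN(Cc1c(Cl)cccc1Cl)C2` — in a functional assay on HL-60 cells (Homo sapiens) for antiproliferative activity, with a stated time of 24 h (on this read-out lower numbers stand for stronger inhibition and higher numbers for weaker inhibition), compound 1 gives 10600 nM.
Compound 2, `Cc1ccc(C(=O)Nc2sc3c(c2C(N)=O)CCN(Cc2c(Cl)cccc2Cl)C3)cc1` — in this assay compound 2 gives 10000 nM.
Compound 3, `NC(=O)c1c(NC(=O)c2ccccc2Cl)sc2c1CCN(C(=S)Nc1ccccc1C(F)(F)F)C2` — in this assay compound 3 gives 10600 nM.

All three measured compounds share a core carrying a primary amide and an amide-linked aryl group, and all three give numbers that sit close together. Compound 3 stands level with compound 1 at the digits shown, and its difference from compound 2 is within the scatter, so none of the three can be called more or less active than another.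

Compound 1 and compound 2 differ in one place: methyl in place of trifluoromethyl on an aromatic carbon. That change gave a 1.1-fold lower number from compound 1 to compound 2 (0.03 log units; within the scatter), a step that is within the scatter.

Compound 4, `Cc1ccccc1NC(=S)N1CCc2c(sc(NC(=O)c3ccccc3Cl)c2C(N)=O)C1`, has not yet been measured. It differs from compound 3 by methyl in place of trifluoromethyl on an aromatic carbon. Going by the values given here, this is the same kind of change as the one from compound 1 to compound 2, but not the same: in compound 1 the group sits para to a large group, in compound 3 it sits ortho to a large group. The difference between the core of compound 1 and the core of compound 3 is not broken down here.

Because a 1.1-fold lower number from compound 1 to compound 2 (0.03 log units; within the scatter) was within the scatter, a similarly small step, a 1.1-fold lower number from compound 3 to compound 4 (0.03 log units; within the scatter), is expected. Compound 4 is estimated at 10000 nM, with a range from 5000 nM to 21000 nM.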

Compound 4, half-maximal inhibitory concentration: 22600 nM
Compound 4: middle estimate off by 2.3-fold (0.35 log units), on the low side; the whole stated range lies below it.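

In this assay, putting methyl in place of trifluoromethyl on an aromatic carbon gave a 2.1-fold higher number from compound 3 to compound 4 (0.33 log units; beyond the scatter), a modest step and the only one in this small set that stands clear of the usual noise. Set beside the earlier example of this change, however, it cannot be told apart from that step, even though only one of the two stands clear of the noise: the same change on two cores in this assay, a 1.1-fold lower number (0.03 log units; within the scatter) from compound 1 to compound 2 and a 2.1-fold higher number (0.33 log units; beyond the scatter) from compound 3 to compound 4, 2.3-fold (0.35 log units) apart, within the scatter of two such steps Carrying the change from one core to another is therefore not shown to alter its effect, but two pairs cannot prove that the effect is the same on both, and as they differ both in the core and in where the group sits, the influence of either cannot be separated.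

As far as these compounds go, it remains open how the 2-methylphenyl part of compound 4 would compare with rings carrying other groups at the same place, such as a methoxy group, an amine or a carboxylic acid, or with a ring carrying no group there at all. It also remains open whether any change to this series could give a number far lower than those shown, which run from compound 2 at 10000 nM to compound 4 at 22600 nM.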